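The source may report more compounds than this note shows. Statements on the series, on what has been measured and on what is new or still open speak of the compounds shown alone.

The assay throughout is a functional assay on MCF7 cells (Homo sapiens) for cytotoxicity, read by MTT assay, with stated times of 6 h and 48 h (on this read-out lower numbers stand for stronger inhibition and higher numbers for weaker inhibition), so that a smaller number means a compound that damages the cells at a lower concentration. Compound 1, whose structure is `Cn1c(/C=C/C(=O)c2ccccc2)cc(Br)c1Br`, gives 35400 nM. Compound 3, with the structure `O=C(/C=C/c1cc(Br)c(Br)[nH]1)c1ccccc1`, keeps the same skeleton and differs by hydrogen in place of methyl on an aromatic nitrogen. In this assay compound 3 gives 12200 nM, so the change produces a 2.9-fold lower number from compound 1 to compound 3 (0.46 log units; beyond the scatter).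

Compound 2 has the structure `COc1ccc(C(=O)/C=C/c2cc(Br)c(Br)n2C)c(OC)c1`. Its core differs from that of compound 1 in more than one place, and that difference is not broken down here. In this assay compound 2 gives 80 nM, the lowest number among the three measured compounds, far removed from the other two.

Compound 4, whose structure is `COc1ccc(C(=O)/C=C/c2cc(Br)c(Br)[nH]2)c(OC)c1`, is not yet measured. It is related to compound 2 by hydrogen in place of methyl on an aromatic nitrogen. The surroundings of the place are the same, word for word, as in the change from compound 1 to compound 3, so this is the same change made on a different core. For the measured compounds named here, that earlier case is the only guide available, and it involved a core that starts from a much higher number. The expected step is a 1.6-fold lower number from compound 2 to compound 4 (0.20 log units; within the scatter), which is estimated to be smaller than the measured one. That expectation rests on a 2.9-fold lower number from compound 1 to compound 3 (0.46 log units; beyond the scatter) being only modest in size. On this basis compound 4 is expected to give 50 nM in this assay. Compound 4 is estimated to fall between 12 nM and 200 nM.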

Compound 4, half-maximal inhibitory concentration: 30 nM
Compound 4: middle estimate off by 1.7-fold (0.22 log units), on the high side; measured number inside the range.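

In this assay, putting hydrogen in place of methyl on the aromatic nitrogen gives a 2.7-fold lower number from compound 2 to compound 4 (0.43 log units; beyond the scatter), and so the lowering seen on the core of compound 1 appears again on a core with far lower numbers. Set side by side, the two cases agree in size: the same change on two cores in this assay, a 2.9-fold lower number (0.46 log units; beyond the scatter) from compound 1 to compound 3 and a 2.7-fold lower number (0.43 log units; beyond the scatter) from compound 2 to compound 4, 1.1-fold (0.04 log units) apart, within the scatter of two such steps. On these two cores, then, the change carries over from one to the other at much the same size, and a step measured on one core was a fair guide to the step on the other; but two pairs are all that is shown, and they tell neither why hydrogen gives the lower number nor whether the step would hold on a third core.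

Only hydrogen and methyl appear on this nitrogen, which leaves open what a longer chain such as ethyl, or a carboxylic acid carried on a short chain, would do there. Also open is which part of the difference in core accounts for the wide gap between compound 1 at 35400 nM and compound 2 at 80 nM, as those two compounds differ in more than one place.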